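The source may report more compounds than this note shows. Statements on the series, on what has been measured and on what is new or still open speak of the compounds shown alone.

Measured so far:
compound 1 `CCOC(=O)C1=Cc2ccccc2OC1(OCc1cn(-c2ccc(F)cc2)nn1)C(F)(F)F` — 7300 nM
compound 2 `CCOC(=O)C1=Cc2ccccc2OC1(OCc1cn(-c2ccc(F)c([N+](=O)[O-])c2)nn1)C(F)(F)F` — 11900 nM

In a functional assay on A549 cells (Homo sapiens) for inhibition, read by MTT assay, with a stated time of 24 h (a higher number here means a weaker inhibitor, a lower number a stronger inhibitor), compound 2 gives 11900 nM. Among the measured compounds shown here, its only neighbour is compound 1, and the step of a 1.6-fold higher number from compound 1 to compound 2 (0.21 log units; within the scatter) leaves the pair within the scatter. Compound 3 `CCOC(=O)C1=Cc2ccccc2OC1(OCc1cn(CC(=O)Nc2ccccc2F)nn1)C(F)(F)F` is not yet measured. It differs from compound 2 by ((2-fluorophenyl)carbamoyl)methyl in place of 4-fluoro-3-nitrophenyl on an aromatic nitrogen. For the measured compounds named here, the single measured step, a 1.6-fold higher number from compound 1 to compound 2 (0.21 log units; within the scatter), concerns a small alteration of the very group that now leaves, so it says little about exchanging that group entirely; no shift beyond the scatter is expected in either direction. Compound 3 is therefore estimated at 10000 nM, between 3000 nM and 35000 nM. That estimate amounts to an expected step of a 1.2-fold lower number from compound 2 to compound 3 (0.08 log units; within the scatter).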

Compound 3, half-maximal inhibitory concentration: 50100 nM
Beside the measured number, compound 3's estimate is 5.0-fold (0.70 log units) below it, outside the stated range (above it).
By their numbers in this assay, from the lowest: compounds 1 and 2 (each within the scatter of the next); then compound 3.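

In this assay the group on the aromatic nitrogen proves to matter once it is replaced whole: ((2-fluorophenyl)carbamoyl)methyl gives a 4.2-fold higher number from compound 2 to compound 3 (0.62 log units; beyond the scatter) and a 6.9-fold higher number from compound 1 to compound 3 (0.84 log units; beyond the scatter) and both steps lie beyond the scatter. Compound 3 is thus a weaker inhibitor than either compound carrying an aromatic ring directly on that nitrogen, a difference the nitro step alone never revealed. Nothing available explains this loss.

The compounds shown do not separate the contribution of the amide from that of the added methylene link. A benzyl group or a simple 2-aminoethyl chain on that nitrogen remains an open case.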